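The source may report more compounds than this note shows. Statements on the series, on what has been measured and on what is new or still open speak of the compounds shown alone.

Working notes. Compound 1 `O=[N+]([O-])c1cn2c(n1)OC[C@@H](OCc1ccc(-c3ccc(F)cc3)s1)C2` and compound 2 `O=[N+]([O-])c1cn2c(n1)OC[C@@H](OCc1ccc(-c3ccc(OC(F)(F)F)cc3)s1)C2` share one core and differ only in trifluoromethoxy in place of fluoro on an aromatic carbon. In an ADME assay on Vero cells (Chlorocebus sabaeus) for cytotoxicity, with a stated time of 72 h (on this read-out higher numbers stand for weaker inhibition and lower numbers for stronger inhibition), compound 1 gives > 128000 nM, which is a limit of the assay. In this assay compound 2 gives > 128000 nM, again a limit. The paired measurement therefore yields a step that the two limits leave unreadable from compound 1 to compound 2. Compound 3 `Cn1nc(-c2ccc(F)cc2)cc1CO[C@@H]1COc2nc([N+](=O)[O-])cn2C1` carries a different core; the difference between the two cores is not broken down here. In this assay compound 3 gives > 128000 nM, also a limit. Taken together, (the limit of > 128000 nM in this assay, at which 3 of the 3 values shown sit). Compound 4 `Cn1nc(-c2ccc(OC(F)(F)F)cc2)cc1CO[C@@H]1COc2nc([N+](=O)[O-])cn2C1` stands to compound 3 as compound 2 stands to compound 1, with trifluoromethoxy in place of fluoro on an aromatic carbon at the same place, so it is the same change. The expected step is a number no higher from compound 3 to compound 4 (the limit leaves the size open), resting on a step that the two limits leave unreadable from compound 1 to compound 2 and on (the limit of > 128000 nM in this assay, at which 3 of the 3 values shown sit). For compound 4 the estimate is 128000 nM, most probably reported once more as a limit.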

Compound 4, half-maximal inhibitory concentration: > 128000 nM
Compound 4 was reported as a limit; the forecaster's own chance of this, stated with the estimate: 85%; the middle value lies on the limit itself.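

For the compounds shown here, compound 3 and compound 4 each give only a limit in this assay, and no step between them can be read. The compounds shown leave open whether trifluoromethoxy in place of fluoro changes the read-out at all: the limit of > 128000 nM in this assay, at which 4 of the 4 values shown sit.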